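The source may hold more compounds than are shown below. What is called first, only, known or untested is meant among the compounds shown, and "the series" means these compounds.

Among the compounds with values here, in a physicochemical assay for lipophilicity (a lower number here means a more polar compound, a higher number a more lipophilic compound), compound 2 `C[C@H]1CC[C@@H]2[C@@H](OC(=O)[C@]23CC(c2c(F)c(F)c(F)c(F)c2F)N(c2ccccc2)O3)[C@]2(C)C(=O)C=C[C@@]12O` gives 3.72, the higher of the two numbers so far, while compound 1 `C[C@H]1CC[C@@H]2[C@@H](OC(=O)[C@]23CC(c2ccc(F)cc2)N(c2ccccc2)O3)[C@]2(C)C(=O)C=C[C@@]12O` gives 3.35. The next compound on the shared core is compound 3 `COc1cccc(C2C[C@@]3(ON2c2ccccc2)C(=O)O[C@@H]2[C@H]3CC[C@H](C)[C@]3(O)C=CC(=O)[C@@]23C)c1`, and the change is this: 3-methoxyphenyl in place of 2,3,4,5,6-pentafluorophenyl on a saturated ring carbon. Within the data shown here, one measured step bears on it: a number 0.37 log units higher from compound 1 to compound 2 (beyond the scatter), which also involved 2,3,4,5,6-pentafluorophenyl on that saturated ring carbon. Among the measured compounds shown here, no measured step involves 3-methoxyphenyl, so that modest step serves only as a guide, and a fall of similar size is expected: a number 0.42 log units lower from compound 2 to compound 3 (beyond the scatter). The estimate for compound 3 is 3.3, with an expected range of 3 to 3.6.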

Compound 3, partition coefficient: 3.25
The estimate for compound 3 lay 0.05 log units above the measured number; the measured number falls inside the stated range.
By their numbers in this assay, from the lowest: compounds 3 and 1 (each within the scatter of the next); then compound 2.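

In this assay, 3-methoxyphenyl in place of 2,3,4,5,6-pentafluorophenyl on this saturated ring carbon gives a number 0.47 log units lower from compound 2 to compound 3 (beyond the scatter), so a second partner now separates from the pentafluorophenyl group by a modest step. In place of 4-fluorophenyl, the same group gives a number 0.10 log units lower from compound 1 to compound 3 (within the scatter), so these two substituted phenyl groups cannot be told apart here, and among the three compounds only compound 2 stands apart. Nothing available accounts for these numbers. The compounds shown leave open how an amine or a carboxylic acid on this ring carbon would read in this assay, and whether an unsubstituted phenyl group would read with compound 1 and compound 3.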